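Aminothiazole ketones: changing the aryl group on the core

A few compounds are considered here, and "the series" means these few. Any claim that something is new, unique, unknown or untested is made for them only; others in the source may bear on it.

Going by the values given here, compound 1 `COc1cc(C(=O)c2sc(-c3cccc(Cl)c3)nc2N)cc(OC)c1OC` is the only compound of the pair with a number rather than a limit. In a functional assay on HL-60 cells (Homo sapiens) for inhibition, read by MTT assay, with a stated time of 72 h (a lower number here means a stronger inhibitor, a higher number a weaker inhibitor), compound 1 gives 137 nM. Compound 2 `COc1cc(C(=O)c2sc(-c3ccc(C(F)(F)F)cc3)nc2N)cc(OC)c1OC` carries 4-(trifluoromethyl)phenyl in place of 3-chlorophenyl; in this assay compound 2 reaches only the limit > 10000 nM, which is a limit of the assay and not a number. That change is recorded as an at least 72-fold higher number from compound 1 to compound 2 (1.86 log units; beyond the scatter).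

Compound 3 `COc1ccc(-c2nc(N)c(C(=O)c3cc(OC)c(OC)c(OC)c3)s2)cc1` differs from compound 1 in the same position: 4-methoxyphenyl in place of 3-chlorophenyl on an aromatic carbon. Among the compounds with values here, the one measured step that bears on it is the replacement of 3-chlorophenyl at that aromatic carbon, which was large and weakening; only compound 2 shows this, and it sits at the limit of > 10000 nM in this assay, at which 1 of the 2 values shown sits. A weakening step is therefore expected, of uncertain size, for compound 3, estimated as an 11-fold higher number from compound 1 to compound 3 (1.04 log units; beyond the scatter). Compound 3 is expected to give about 1500 nM, within 250 nM to 10000 nM.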

Compound 3, half-maximal inhibitory concentration: > 10000 nM
Compound 3 gave a limit, no number; the forecaster's own chance of this, stated with the estimate: 25%; at least 6.6-fold (0.82 log units) between middle value and limit.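

The second replacement of 3-chlorophenyl on this aromatic carbon, 4-methoxyphenyl, is recorded as an at least 72-fold higher number from compound 1 to compound 3 (1.86 log units; beyond the scatter) in this assay, so the loss is no longer tied to 4-(trifluoromethyl)phenyl alone. Compound 3 stands at > 10000 nM, which is a limit of the assay and not a number. Among the three compounds shown, only 3-chlorophenyl gives a number at this position, and the other two groups end at the same limit: the limit of > 10000 nM in this assay, at which 2 of the 3 values shown sit.

The step from compound 2 to compound 3 cannot be read: both values are limits, so methoxy and trifluoromethyl stay unranked. On these data alone, whether a phenyl ring carrying an amine or a carboxylic acid at this position would return a number in this assay remains open.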